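The source may hold more compounds than are shown below. What is called first, only, known or untested is meant among the compounds shown, and "the series" means these compounds.

Measured compounds in hand:

compound 1 `O=S(=O)(CCCN1CCc2cc(OCc3ccccc3)ccc2C(O)C1)c1ccccc1` — 349 nM
compound 2 `CN(Cc1ccccc1)C(=O)CN1CCc2cc(OCc3ccccc3)ccc2C(O)C1` — reported only as a limit, > 1000 nM
compound 3 `OC1CN([C@H]2CC[C@@H](c3ccccc3)CC2)CCc2cc(OCc3ccccc3)ccc21` — 10 nM

In an assay for displacement of a labelled ligand from Sigma non-opioid intracellular receptor 1 (Cavia porcellus), read by scintillation counting, with a stated time of 180 min (on this read-out higher numbers stand for weaker inhibition and lower numbers for stronger inhibition), compound 3 gives the lowest number of the two numbers reported; the nearest is compound 1, whose value lies beyond the scatter above it. For compound 2 the assay returns a limit and no number (the limit of > 1000 nM in this assay, at which 1 of the 3 values shown sits).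

Compound 4 `OC1CN([C@H]2CC[C@H](c3ccccc3)CC2)CCc2cc(OCc3ccccc3)ccc21` is the next point. Its relation to compound 3 is the two compounds have the same atoms and bonds; at least one stereo element is drawn with a configuration in one of them and without one in the other: 2 of 3 stereo elements differ; a stereocentre at a saturated ring carbon is drawn s in compound 3 and r in compound 4; a stereocentre at a saturated ring carbon is drawn s in compound 3 and r in compound 4: the two compounds have the same atoms and bonds; 2 of 3 stereo elements differ, a stereocentre at a saturated ring carbon drawn s in compound 3 and r in compound 4, and a second such stereocentre likewise drawn s in compound 3 and r in compound 4. Among the compounds with values here, no measured pair differs only in this way, so no measured step gives the size to expect. The step in this assay is expected to be small, towards a somewhat higher number or none beyond the scatter. Compound 4 is estimated at 25 nM (6 nM to 100 nM), which is expected to correspond to a 2.5-fold higher number from compound 3 to compound 4 (0.40 log units; beyond the scatter).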

Compound 4, inhibition constant: 386 nM
The estimate for compound 4 lay 15-fold (1.19 log units) below the measured number; the measured number lies above the stated range.
By their numbers in this assay, from the lowest: compound 3; then compounds 1 and 4 (each within the scatter of the next). At a limit, above all of these: compound 2.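

In this assay, the series now has its first step between compounds that differ in one place: a 39-fold higher number from compound 3 to compound 4 (1.59 log units; beyond the scatter). Within the data shown here, with atoms and bonds unchanged, only the two stereocentres at saturated ring carbons separate these compounds, so configuration at this position alone goes with a large step, something the earlier compounds, which differ from one another in more than one place, could not show. This reading carries one reservation about how the two structures are drawn: the fact that one of compounds 3 and 4 is drawn with a defined configuration and the other without, at the place where they differ

As far as these compounds go, the contribution of each stereocentre on its own stays open, as does any role for the third stereo element, which does not differ between compound 3 and compound 4. Also open, from the compounds shown here alone, is whether a step of this size persists with a pyridine or a carboxylic acid in place of the phenyl group.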